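The source may report more compounds than this note shows. Statements on the series, on what has been measured and on what is new or still open speak of the compounds shown alone.

In a physicochemical assay for lipophilicity (on this read-out higher numbers stand for higher lipophilicity and lower numbers for lower lipophilicity), compound 1 `Brc1ccc(N(CC2CC2)C2=NCCN2)c(Br)c1` gives -0.31 and compound 2 `Brc1cccc(N(CC2CC2)C2=NCCN2)c1Br` gives -0.41 while compound 3 `CCCN(C1=NCCN1)c1c(Br)cccc1Br` gives -0.55 when measured the same way. Compound 3 therefore stands within the scatter of both other compounds, and the three values show no order that can be relied on. No two of these compounds differ in one place only, so no measured step is available as a guide.

Compound 4 `CC(C)N(C1=NCCN1)c1c(Br)cccc1Br` has not yet been measured in this assay and holds the same atoms as compound 3 joined differently. The change is isopropyl in place of propyl on a nitrogen on an aromatic ring with isopropyl in place of propyl on a nitrogen on an aromatic ring. The data hold no measured case of this swap. Among the compounds with values here, the only guide is the narrow spread of the series: compound 2 at -0.41 and compound 3 at -0.55 lie within the scatter of each other although they differ in more than one place. A step beyond the scatter is therefore not expected in this assay and at most a slight drop is anticipated. The expected step is a number 0.10 log units lower from compound 3 to compound 4 (within the scatter) and it is estimated to stay within the scatter. Compound 4 is expected at -0.65 with -1 to -0.3 as the estimated range.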

Compound 4, distribution coefficient: -0.82
Estimate against measurement, compound 4: 0.17 log units above, within the range that was stated.
By their numbers in this assay, from the lowest: compounds 4, 3, 2 and 1 (each within the scatter of the next, the first and the last beyond it).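

In this assay, within the data shown here, isopropyl in place of propyl on a nitrogen on an aromatic ring provides the first measured step between compounds differing in one place, a number 0.27 log units lower from compound 3 to compound 4 (within the scatter), and this step stays within the scatter. Propyl and isopropyl hold the same atoms, so this pair isolates how the chain is joined at this nitrogen, and here that rearrangement alone does not separate the two compounds beyond the scatter. This single pair gives no sign that this position responds to this change on this read-out, and no supporting measurement is available to explain the size of the step.

Going by these compounds, whether a longer chain such as butyl, or a chain carrying a hydroxyl group or an amine, on the same nitrogen would give a step beyond the scatter remains open. Also open, on these data alone, is whether the same swap of propyl for isopropyl on the core of compound 2 would give a step of similar size.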